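From Aryl Ether to Benzylamine: Awaiting the Cell Result

The source may report more compounds than this note shows. Statements on the series, on what has been measured and on what is new or still open speak of the compounds shown alone.

Compound 1 `Nc1cc(N)c2nc(-c3ccccc3)c(Oc3ccc(Cl)c(Cl)c3)nc2c1` was examined in a functional assay on DU-145 cells (Homo sapiens) for inhibition, read by sulforhodamine B assay, with a stated time of 48 h; on this read-out lower numbers stand for higher toxicity in this test and higher numbers for lower toxicity in this test. In this assay compound 1 gives < 100000 nM, which is a limit of the assay rather than a number. Compound 2 `CCOC(=O)[C@H](CCC(=O)O)NC(=O)c1ccc(Sc2nc3cc(N)cc(N)c3nc2-c2ccccc2)cc1` sits in the same situation: in this assay compound 2 gives < 100000 nM, again a limit. Compound 3 `COc1cc(CNc2nc3cc(N)cc(N)c3nc2-c2ccccc2)cc(OC)c1OC` in this assay gives < 50200 nM, also a limit. Accordingly, the limit of < 100000 nM in this assay, at which 2 of the 3 values shown sit, and the limit of < 50200 nM in this assay, at which 1 of the 3 values shown sits, are all that is known, and no measured step between these compounds can be drawn. Compound 4 `Nc1cc(N)c2nc(-c3ccccc3)c(NCc3ccc(F)cc3)nc2c1` differs from compound 1 by (4-fluorobenzyl)amino in place of 3,4-dichlorophenoxy on an aromatic carbon. With only limits in hand, no direction beyond the scatter can be read from the data. Compound 4 is expected to give 40000 nM in this assay, within 5000 nM to 100000 nM. The expected step that the limit leaves unreadable from compound 1 to compound 4 remains inside what these limits allow.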

Compound 4, concentration lethal to 50% of the cells: 9770 nM
Compound 4: the middle estimate sits 4.1-fold (0.61 log units) above what was measured, and the stated range covers the measured number.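

Within the data shown here, the value of compound 1 in this assay is a limit, and no step to compound 4 can be read from it. On these data alone, whether (4-fluorobenzyl)amino in place of 3,4-dichlorophenoxy shifts this read-out at all remains open.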